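This account rests on a few compounds, and the source may have more. Where it says the series, first, only, none or still open, it means among the compounds named here.

Working notes on the oxadiazole-free description of the series: compound 1 `c1ccc(-c2nnc(-c3ccc(-n4cccc4)cc3)o2)cc1` stands in an ADME assay on A549 cells (Homo sapiens) for cytotoxicity, read by MTT assay, with a stated time of 72 h (a higher number here means a weaker inhibitor, a lower number a stronger inhibitor), at 256000 nM. Compound 2 `O=[N+]([O-])c1cccc(-c2nnc(-c3ccc(-n4cccc4)cc3)o2)c1` gives 256000 nM in this assay, and the step of no change at the digits printed from compound 1 to compound 2 (within the scatter) shows nitro in place of hydrogen on an aromatic carbon leaving the number unchanged. Compound 3 `O=C(NNC(=O)c1ccccc1Br)c1ccc(-n2cccc2)cc1`, built on a different core, gives 201000 nM in this assay; its value and that of compound 1 lie within the scatter of each other, so compound 1 is level with compound 2 and not separable from compound 3.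

Compound 4 `Brc1ccccc1-c1nnc(-c2ccc(-n3cccc3)cc2)o1` is not yet measured. It differs from compound 1 by bromo in place of hydrogen on an aromatic carbon, the phenyl becoming 2-bromophenyl. Within the data shown here, the one measured step on the shared core, no change at the digits printed from compound 1 to compound 2 (within the scatter), was flat, and compound 3 carries the same 2-bromophenyl on another core with a value, 201000 nM, that gives no sign of a shift. The expected step is therefore a 1.1-fold lower number from compound 1 to compound 4 (0.03 log units; within the scatter), nothing beyond the scatter. Compound 4 is estimated at 240000 nM in this assay, with a range from 110000 nM to 520000 nM.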

Compound 4, half-maximal inhibitory concentration: 252000 nM
For compound 4 the middle estimate is 1.1-fold (0.02 log units) below the measured one; measured number inside the range.
By their numbers in this assay, from the lowest: compounds 3, 4, 1 and 2 (each within the scatter of the next).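

The step of a 1.0-fold lower number from compound 1 to compound 4 (0.01 log units; within the scatter) in this assay shows that bromo in place of hydrogen on an aromatic carbon leaves the number within the scatter. This extends the flat picture on the shared core to a second substituent, and to a place ortho to a large group, which the nitro step did not show. Nothing measured here accounts for the flat result.

From the compounds shown here alone, whether an amine, a carboxylic acid or a longer chain at this place would move the number beyond the scatter remains open. On the shared core, the three compounds shown stay within the scatter of one another, so they give no ranking of the substituents and do not show whether any change on this ring can shift the number.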